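Extending the Alkyl Chain on the Shared Macrocyclic Core

The source may hold more compounds than are shown below. What is called first, only, known or untested is meant among the compounds shown, and "the series" means these compounds.

Three compounds share one macrocyclic core and differ only in the alkyl group on one amide-type nitrogen in a ring. Compound 1 `CCN1C(=O)[C@@H](C)NC(=O)[C@@H]2Cc3ccc(OC)c(c3)Oc3ccc(cc3)C[C@@H](C(=O)N2C)N(C)C(=O)[C@H](C)NC(=O)[C@H](Cc2ccc(OC)cc2)N(C)C(=O)[C@@H]1C` gives 43.7 nM in a functional assay on P388 cells (Mus musculus) for cytotoxicity; on this read-out higher numbers stand for weaker inhibition and lower numbers for stronger inhibition. Compound 2 `CCCN1C(=O)[C@@H](C)NC(=O)[C@@H]2Cc3ccc(OC)c(c3)Oc3ccc(cc3)C[C@@H](C(=O)N2C)N(C)C(=O)[C@H](C)NC(=O)[C@H](Cc2ccc(OC)cc2)N(C)C(=O)[C@@H]1C` gives 3.98 nM in this assay, and compound 3 `CCCCN1C(=O)[C@@H](C)NC(=O)[C@@H]2Cc3ccc(OC)c(c3)Oc3ccc(cc3)C[C@@H](C(=O)N2C)N(C)C(=O)[C@H](C)NC(=O)[C@H](Cc2ccc(OC)cc2)N(C)C(=O)[C@@H]1C` gives 12 nM in this assay. Compound 3 therefore stands second highest of the three numbers, between compound 2 and compound 1.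

The step to compound 4 `CCCCCN1C(=O)[C@@H](C)NC(=O)[C@@H]2Cc3ccc(OC)c(c3)Oc3ccc(cc3)C[C@@H](C(=O)N2C)N(C)C(=O)[C@H](C)NC(=O)[C@H](Cc2ccc(OC)cc2)N(C)C(=O)[C@@H]1C` is methyl in place of hydrogen on a saturated chain carbon, four bonds along the chain from an amide-type nitrogen in a ring. The same kind of chain extension has been seen twice: an 11-fold lower number from compound 1 to compound 2 (1.04 log units; beyond the scatter) and a 3.0-fold higher number from compound 2 to compound 3 (0.48 log units; beyond the scatter). The first extension helped strongly, the second hurt modestly, so the two known steps point in opposite directions and give no settled trend. The expectation for compound 4 is a step of about a 1.5-fold higher number from compound 3 to compound 4 (0.18 log units; within the scatter), with little confidence in its direction. Compound 4 is thus estimated at 18 nM in this assay, within a range of 5 nM to 60 nM.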

Compound 4, half-maximal inhibitory concentration: 21.4 nM
Compound 4: the middle estimate sits 1.2-fold (0.08 log units) below what was measured; measured number inside the range.
By their numbers in this assay, from the lowest: compound 2; then compounds 3 and 4 (each within the scatter of the next); then compound 1.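

In this assay, methyl in place of hydrogen on a saturated chain carbon, four bonds along the chain from an amide-type nitrogen in a ring, gives a 1.8-fold higher number from compound 3 to compound 4 (0.25 log units; within the scatter), so at this chain length the extension no longer moves the number beyond the scatter. The longest chain shown stays well behind the best of the series, with a 5.4-fold higher number from compound 2 to compound 4 (0.73 log units; beyond the scatter), and keeps only a modest edge over the shortest, with a 2.0-fold lower number from compound 1 to compound 4 (0.31 log units; beyond the scatter). The effect of adding the same group therefore depends strongly on the chain that receives it: the same change on two cores in this assay, an 11-fold lower number (1.04 log units; beyond the scatter) from compound 1 to compound 2 and a 1.8-fold higher number (0.25 log units; within the scatter) from compound 3 to compound 4, 20-fold (1.29 log units) apart, beyond the scatter of two such steps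

The compounds shown leave open whether a longer chain would push the number further up. They also leave open whether a branched chain, or an amine or hydroxyl at the chain end, could match compound 2 at 3.98 nM.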